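Compound 3 to compound 4: one group exchanged

The source may report more compounds than this note shows. Statements on the series, on what has been measured and on what is new or still open speak of the compounds shown alone.

Compound 1 `COc1cc(-c2ccnc3cc(-c4ccc(Cl)cc4)nn23)cc(OC)c1OC` gives 1490 nM
Compound 2 `COc1cc(-c2ccnc3cc(-c4ccc(N(C)C)cc4)nn23)cc(OC)c1OC` gives 378 nM
Compound 3 `C=Cc1ccc(-c2cc3nccc(-c4cc(OC)c(OC)c(OC)c4)n3n2)cc1` gives 882 nM

In a functional assay on HeLa cells (Homo sapiens) for inhibition, read by CCK-8 assay, with a stated time of 48 h (a higher number here means a weaker inhibitor, a lower number a stronger inhibitor), compound 3 gives 882 nM and holds the second highest of the three numbers. Two measured steps reach it, a 1.7-fold lower number from compound 1 to compound 3 (0.23 log units; within the scatter) and a 2.3-fold higher number from compound 2 to compound 3 (0.37 log units; beyond the scatter), and the largest on this carbon is a 3.9-fold lower number from compound 1 to compound 2 (0.60 log units; beyond the scatter). Compound 4 `COc1cc(-c2ccnc3cc(-c4ccc(-c5cnn(C)c5)cc4)nn23)cc(OC)c1OC` differs from compound 3 by 1-methyl-1H-pyrazol-4-yl in place of vinyl on an aromatic carbon, with 1-methyl-1H-pyrazol-4-yl in place of vinyl on an aromatic carbon. Within the data shown here, no measured compound carries this group, and the measured steps at this place are all modest or smaller, so no step beyond the scatter is expected. The expected step is a 1.3-fold lower number from compound 3 to compound 4 (0.10 log units; within the scatter). For compound 4 the estimated value is 700 nM, with an expected range from 250 nM to 1900 nM.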

Compound 4, half-maximal inhibitory concentration: 1830 nM
Beside the measured number, compound 4's estimate is 2.6-fold (0.42 log units) below it, within the range that was stated.
By their numbers in this assay, from the lowest: compound 2; then compounds 3, 1 and 4 (each within the scatter of the next, the first and the last beyond it).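

In this assay, the first ring placed at this carbon brought no gain: a 2.1-fold higher number from compound 3 to compound 4 (0.32 log units; beyond the scatter), and a 1.2-fold higher number from compound 1 to compound 4 (0.09 log units; within the scatter) leaves compound 4 not separated from the chloro compound. With a 4.8-fold higher number from compound 2 to compound 4 (0.68 log units; beyond the scatter), dimethylamino still gives the lowest number of the four groups at this position. No measurement shown here accounts for the rise with 1-methyl-1H-pyrazol-4-yl. The compounds shown leave open whether a primary amine, a morpholine ring or a methoxy group at this carbon would match dimethylamino, and whether a phenyl ring would behave like the pyrazole.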